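Notes on compound 1 and the untested compound 4

The compounds below may be only part of what the source reports. "The series", "measured", "known", "first", "only" and "open" are said of these compounds alone.

Measured so far:
compound 1 `CCC/N=C(/NC#N)NCCCCn1nc(-c2ccccc2)ccc1=O`: > 100 mg/kg
compound 2 `C/N=C(/NC#N)NCCCCCn1nc(-c2ccccc2)c(C)cc1=O`: > 100 mg/kg
compound 3 `C/N=C(/NC#N)NCCCCn1nc(Nc2ccccc2)ccc1=O`: > 100 mg/kg

In a functional assay on the whole organism (stomach) with Rattus norvegicus as the target (on this read-out higher numbers stand for an effect only at larger amounts of compound and lower numbers for an effect already at smaller amounts), compound 1 gives > 100 mg/kg; this is a limit of the assay, not a number. Compound 2 likewise reaches only a limit, > 100 mg/kg. Compound 3 also stops at a limit, > 100 mg/kg. All three values thus sit at the limit of > 100 mg/kg in this assay, at which 3 of the 3 values shown sit, so compound 1 cannot be placed above or below the other two. Among the measured compounds shown here, no step between measured compounds can be computed. Compound 4 `CC/N=C(\S)NCCCCn1nc(-c2ccccc2)ccc1=O` differs from compound 1 by a group of 5 heavy atoms (3 carbon, 1 nitrogen, 1 sulfur; no ring) in place of a group of 8 heavy atoms (5 carbon, 3 nitrogen; no ring), on an amine nitrogen. The measured set shows no change that moves the read-out off the limit; the step of a number no higher from compound 1 to compound 4 (the limit leaves the size open) is expected to be none beyond the scatter. Compound 4 is expected to give 100 mg/kg, within a range of 30 mg/kg to 300 mg/kg, most likely reported as a limit again.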

Compound 4, dose for half-maximal effect: 37.2 mg/kg
For compound 4 the middle estimate is 2.7-fold (0.43 log units) above the measured one, and the stated range covers the measured number.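

In this assay, among the compounds shown here, the group of 5 heavy atoms on the amine nitrogen gives an at least 2.6-fold lower number from compound 1 to compound 4 (0.42 log units; beyond the scatter), so a change at this position can bring the read-out off the limit, which the earlier compounds did not show. The value of compound 1 is a limit of the assay, so the step has a lower bound only. Compound 4 is the only compound shown with a number: the limit of > 100 mg/kg in this assay, at which 3 of the 4 values shown sit.

Still open, on these data alone, is whether the sulfur itself matters, as a matching group with oxygen in its place would show. Also open, as far as these compounds go, is how a longer chain on the same nitrogen would read.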